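Extending the Acid Chain on a Shared Core

The source may hold more compounds than are shown below. What is called first, only, known or untested is meant among the compounds shown, and "the series" means these compounds.

Within the data shown here, compound 2 `CN(c1cnccc1SCCCCC(=O)O)c1ccc(C#N)c2ccccc12` is one of three compounds measured in an assay on HEK293 cells for inhibition of solute carrier family 22 member 12 (Homo sapiens), read by scintillation counting, with stated times of 30 min and 15 min; a higher number here means a weaker inhibitor, a lower number a stronger inhibitor. Compound 2 gives 3580 nM, the lowest of the three numbers, though all three lie within the scatter of one another: compound 3 `N#Cc1ccc(Oc2cnccc2SCCCCCCC(=O)O)c2ccccc12` gives 3780 nM, and compound 1 `CC(C)(Sc1ccncc1Oc1ccc(C#N)c2ccccc12)C(=O)O` gives 5210 nM. Among the measured compounds shown here, the only single-place step among the measured compounds, from compound 1 to compound 3, reads a 1.4-fold lower number from compound 1 to compound 3 (0.14 log units; within the scatter); replacing the branched acid on the sulfur with a longer straight chain did not move the number beyond the scatter.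

Compound 4 `CN(c1cnccc1SCCCCCCC(=O)O)c1ccc(C#N)c2ccccc12` differs from compound 2 in one place: 2-carboxyethyl in place of carboxy on a saturated chain carbon, four bonds along the chain from a sulfur. This lengthens the acid chain on the sulfur while the rest of compound 2 stays unchanged. The step from compound 1 to compound 3 bears on it most directly: there too a longer chain to the acid left the number within the scatter. Compound 3, which already carries the longer chain of compound 4 on a different linker, sits within the scatter of compound 2. No step beyond the scatter is therefore expected in this assay in either direction. The expected step from compound 2 to compound 4 is a 1.0-fold lower number from compound 2 to compound 4 (0.01 log units; within the scatter). Compound 4 is estimated at 3500 nM, within a range from 1500 nM to 8000 nM.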

Compound 4, half-maximal inhibitory concentration: 4640 nM
The estimate for compound 4 lay 1.3-fold (0.12 log units) below the measured number; measured number inside the range.
By their numbers in this assay, from the lowest: compounds 2, 3, 4 and 1 (each within the scatter of the next).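

In this assay, the change from carboxy to 2-carboxyethyl on a saturated chain carbon, four bonds along the chain from a sulfur, gives the first step read on the core of compound 2: a 1.3-fold higher number from compound 2 to compound 4 (0.11 log units; within the scatter), a step that stays within the scatter. Together with the earlier step (a 1.4-fold lower number from compound 1 to compound 3 (0.14 log units; within the scatter)), which was read with a different group at the other end of the sulfur chain and on a different linker, it shows that neither of these two changes to the acid chain moves the number beyond the scatter, and this second case is the first to lengthen a straight chain with everything else in the molecule held fixed. Nothing shown explains why this lengthening leaves the number within the scatter.

On these data alone, whether a shorter chain, such as carboxymethyl, or a still longer chain on the same sulfur would give a step beyond the scatter remains open. Also open, as far as these compounds go, is what would happen at this position if the carboxylic acid at the end of the chain gave way to an amide or an amine.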